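The source may report more compounds than this note shows. Statements on the series, on what has been measured and on what is new or still open speak of the compounds shown alone.

Working notes on the series.

Compound 3 `Cc1ccc(Cn2c(CN3CCN(C(=O)C4CC4)CC3)nc3ccccc32)cc1` is the reference for this step. For the measured compounds named here, in an assay on isolated protein for inhibition of aldehyde dehydrogenase 1A1 (Homo sapiens), read by spectrophotometry, tested at 10 uM (on this read-out higher numbers stand for more inhibition at the one concentration tested (going by the name of the read-out) and lower numbers for less inhibition), compound 3 gives 51.5%, the highest of the three numbers measured so far. Compound 1 `Cc1cccc(Cn2c(CN3CCN(C(=O)c4ccc([N+](=O)[O-])cc4)CC3)nc3ccccc32)c1` gives 24.3% and compound 2 `Cc1cccc(Cn2c(CN3CCN(C(=O)c4ccc(C(F)(F)F)cc4)CC3)nc3ccccc32)c1` gives 22.9%; both sit well below compound 3, beyond the scatter, but each differs from compound 3 in two places at once, so neither pair yields a single-point step.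

Going by the values given here, the only single-point step measured, a number 1.4 percentage points lower from compound 1 to compound 2 (within the scatter), lies on the amide side of the core and is within the scatter.

Compound 4 `CC(C)Cn1c(CN2CCN(C(=O)C3CC3)CC2)nc2ccccc21` is not yet measured. It differs from compound 3 by isopropyl in place of 4-methylphenyl on a saturated chain carbon bound to an aromatic nitrogen. Among the compounds with values here, no measured step touches this position, so the measured data give no direct guide to its size or direction. A change of this size, which removes a ring, is expected to move the number noticeably; compound 4 is expected to give 38%, with a range from 15% to 62%, meaning an expected step of a number 13.5 percentage points lower from compound 3 to compound 4 (beyond the scatter).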

Compound 4, a percentage reported as inhibition, at one concentration (the size of the read-out at that concentration, not a potency): 13.1%
Compound 4: middle estimate off by 24.9 percentage points, on the high side; the whole stated range lies above it.
By their numbers in this assay, from the lowest: compounds 4, 2 and 1 (each within the scatter of the next, the first and the last beyond it); then compound 3.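

In this assay, the group on the saturated chain carbon bound to an aromatic nitrogen has a large bearing on the read-out: a number 38.4 percentage points lower from compound 3 to compound 4 (beyond the scatter), with isopropyl in place of 4-methylphenyl. For the compounds shown here, this is the first measured step at this position, and it lies beyond the scatter, while the only earlier step, trifluoromethyl in place of nitro on an aromatic carbon, stayed within it. Nothing measured here bears on why the number falls.

The change removes the six-membered aromatic ring and also takes the group from seven heavy atoms to three, so the compounds shown do not separate the effect of the ring from that of the atom count. Cyclohexyl at this position would test a ring that is not aromatic, and a longer alkyl chain would test added carbon without a ring.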